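Trading a propargyl chain for vinyl: an expected loss

The source may hold more compounds than are shown below. What is called first, only, known or untested is meant among the compounds shown, and "the series" means these compounds.

Measured so far:
compound 1, `C#CCCCn1c(Cc2cc(OC)c(OC)c(OC)c2)nc2c(N)nc(F)nc21`, 11000 nM
compound 2, `C#CCCn1c(Cc2cc(OC)c(OC)c(OC)c2)nc2c(N)nc(F)nc21`, 25100 nM
compound 3, `C#CCCCn1c(Cc2cc(OC)c(OC)c(OC)c2)nc2c(N)ncnc21`, 24000 nM

All three were tested in a functional assay on MCF7 cells (Homo sapiens) for antiproliferative activity; a lower number here means a stronger inhibitor, a higher number a weaker inhibitor. Compound 3 stands second highest of the three numbers; its value sits within the scatter of compound 2, so the two cannot be ordered, while compound 1 is separated from it by a step beyond the scatter: a 2.2-fold higher number from compound 1 to compound 3 (0.34 log units; beyond the scatter).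

Compound 4, `C=CCCn1c(Cc2cc(OC)c(OC)c(OC)c2)nc2c(N)ncnc21`, has not yet been measured. It differs from compound 3 in one place: vinyl in place of propargyl on a saturated chain carbon, two bonds along the chain from an aromatic nitrogen. The chain is shortened by one carbon and its triple bond becomes a double bond.

Among the measured compounds shown here, one measured step bears on this: a 2.3-fold higher number from compound 1 to compound 2 (0.36 log units; beyond the scatter), where the same chain was also shortened by one carbon. For the measured compounds named here, that step was modest but beyond the scatter, so a step of similar size in the same direction is expected here, with extra uncertainty from the change of triple bond to double bond, which no measured pair covers. Compound 4 is therefore estimated at 45000 nM, expected to fall between 20000 nM and 100000 nM, a step of a 1.9-fold higher number from compound 3 to compound 4 (0.27 log units; within the scatter).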

Compound 4, half-maximal inhibitory concentration: 40700 nM
Estimate against measurement, compound 4: 1.1-fold (0.04 log units) above; the range from low to high includes it.
By their numbers in this assay, from the lowest: compound 1; then compounds 3, 2 and 4 (each within the scatter of the next).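

Compound 1, compound 2 and compound 3 all keep a triple bond in the chain on the aromatic nitrogen, so they could not show what happens when that bond is lost. In this assay, replacing pent-4-yn-1-yl with but-3-en-1-yl gives a 1.7-fold higher number from compound 3 to compound 4 (0.23 log units; within the scatter) and so the two compounds cannot be ordered: at this position, on the core without fluoro, a chain with a double bond and a chain with a triple bond give numbers that repeat measurements could not tell apart. The swap shortens the chain and changes its bond in a single move, so the pair cannot assign any share of the step to either part, and no measurement shown offers a reason for the result.

A fully saturated chain such as pentyl, or a chain ending in an amine, would test whether any unsaturated bond matters at this position at all. Going by these compounds, how the but-3-en-1-yl chain behaves on the fluoro-bearing core of compound 1 also remains open.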